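This account rests on a few compounds, and the source may have more. Where it says the series, first, only, none or still open, it means among the compounds named here.

Measured in a functional assay on HCT-116 cells (Homo sapiens) for cytotoxicity, read by MTT assay; on this read-out higher numbers stand for weaker inhibition and lower numbers for stronger inhibition:
- compound 1 `CCn1cc(C(=O)Nc2ccc(C)c([N+](=O)[O-])c2)c(=O)c2cc(F)c(N3CCNC(C)C3)c(F)c21`: 11800 nM
- compound 2 `CCn1cc(C(=O)Nc2ccc(OC)cc2)c(=O)c2cc(F)c(N3CCNC(C)C3)c(F)c21`: 3800 nM

Compound 2 holds the lower of the two numbers in this assay, at 3800 nM. Going by the values given here, the only measured step, a 3.1-fold lower number from compound 1 to compound 2 (0.49 log units; beyond the scatter), is a modest one at the amide-type nitrogen, with the rest of the structure unchanged.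

The next compound, compound 3 `CCn1cc(C(=O)Nc2nccs2)c(=O)c2cc(F)c(N3CCNC(C)C3)c(F)c21`, changes the same place: 1,3-thiazol-2-yl in place of 4-methoxyphenyl on an amide-type nitrogen. This puts 1,3-thiazol-2-yl in place of 4-methoxyphenyl on an amide-type nitrogen. Among the compounds with values here, neither measured compound carries the 1,3-thiazol-2-yl group, so the only guide to size is a 3.1-fold lower number from compound 1 to compound 2 (0.49 log units; beyond the scatter). On that basis, a modest move toward a higher number is expected, smaller than the measured step and with wide uncertainty. The expected step is a 2.1-fold higher number from compound 2 to compound 3 (0.32 log units; beyond the scatter). For compound 3 the estimate is 8000 nM, with an expected range of 2500 nM to 25000 nM.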

Compound 3, half-maximal inhibitory concentration: 8660 nM
For compound 3 the middle estimate is 1.1-fold (0.03 log units) below the measured one, within the range that was stated.
By their numbers in this assay, from the lowest: compound 2; then compounds 3 and 1 (each within the scatter of the next).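

In this assay the amide-type nitrogen also takes a five-membered aromatic ring with 2 hetero atoms, and the change to 1,3-thiazol-2-yl is a 2.3-fold higher number from compound 2 to compound 3 (0.36 log units; beyond the scatter) and so gives up part of what 4-methoxyphenyl held. Set against 4-methyl-3-nitrophenyl, the same group gives a 1.4-fold lower number from compound 1 to compound 3 (0.13 log units; within the scatter) and is not separated from it, so among these three groups only 4-methoxyphenyl stands apart. No supporting data bear on why the numbers fall this way.

Still open, going by these compounds, is whether the methoxy group or the phenyl ring carries the difference, which plain phenyl or 4-hydroxyphenyl on the same nitrogen would help separate. Also open, on these data alone, is how this assay would read a six-membered ring with ring nitrogen, such as pyridin-2-yl, or a phenyl ring bearing a carboxylic acid or an amine.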